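This account rests on a few compounds, and the source may have more. Where it says the series, first, only, none or still open, it means among the compounds named here.

Among the measured compounds shown here, compound 1 `COc1ccc(Oc2c(Br)cc3oc(C(=O)O)cc3c2Br)cc1C(C)C` is one of three compounds measured in a functional assay on HepG2 cells for agonist activity at thyroid hormone receptor (Homo sapiens); on this read-out higher numbers stand for an effect only at larger amounts of compound and lower numbers for an effect already at smaller amounts. In this assay compound 1 gives 1000 nM, level with compound 2 `Cc1cc2c(CC(=O)O)coc2c(C)c1Oc1ccc(O)cc1`, which gives 1000 nM; together these are the highest numbers of the set. Compound 3 `Cc1ccc(CC2CC(=O)NC(=O)S2)c(C)c1Oc1ccc(O)c(C(C)C)c1` stands far apart, giving 0.06 nM, a number far below that of compound 1 and beyond the scatter. Compound 4 `CC(C)c1cc(Oc2c(Br)cc3oc(C(=O)O)cc3c2Br)ccc1O` differs from compound 1 in one place: hydrogen in place of methyl on an oxygen on an aromatic ring. For the measured compounds named here, no measured pair shows this change on its own. Compounds 2 and 3 both carry hydroxy on an aromatic ring, yet their numbers lie far apart, so the weight of the change is uncertain. The estimated step is a 20-fold lower number from compound 1 to compound 4 (1.30 log units; beyond the scatter), toward a lower number. Compound 4 is expected near 50 nM, between 5 nM and 500 nM.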

Compound 4, half-maximal effective concentration: 7 nM
For compound 4 the middle estimate is 7.1-fold (0.85 log units) above the measured one, within the range that was stated.
By their numbers in this assay, from the lowest: compound 3; then compound 4; then compounds 1 and 2 (each within the scatter of the next).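

In this assay, among the compounds shown here, methoxy to hydroxy on the core of compound 1 gives (a 140-fold lower number from compound 1 to compound 4 (2.15 log units; beyond the scatter)), the first pair to show this change on its own. The step is large, so this place on this core is sensitive to hydrogen in place of methyl on the oxygen. No measurement available here accounts for the size of the step. Open, on these data alone, is how an amine or an ethoxy at this place would read. Also open, as far as these compounds go, is whether the same change carries a step of similar size on other cores.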